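Moving the methyl group around the phenyl ring

The source may hold more compounds than are shown below. What is called first, only, known or untested is meant among the compounds shown, and "the series" means these compounds.

Of the compounds shown here, three have been tested in a functional assay on HepG2 cells (Homo sapiens) for inhibition, read by MTT assay, with a stated time of 72 h; on this read-out lower numbers stand for stronger inhibition and higher numbers for weaker inhibition. Compound 1 `CC(C)n1ncc2c(C(=O)NCc3cn(-c4ccc(I)cc4)nn3)cccc21` gives > 40000 nM, which is a limit of the assay rather than a number. Compound 2 `CC(C)n1ncc2c(C(=O)NCc3cn(-c4cccc(Br)c4)nn3)cccc21` gives > 40000 nM, again a limit. Compound 3 `Cc1ccc(-n2cc(CNC(=O)c3cccc4c3cnn4C(C)C)nn2)cc1` gives > 40000 nM, also a limit. Because all three sit at the limit of > 40000 nM in this assay, at which 3 of the 3 values shown sit, the steps a step that the two limits leave unreadable from compound 1 to compound 2, a step that the two limits leave unreadable from compound 1 to compound 3 and a step that the two limits leave unreadable from compound 2 to compound 3 cannot be sized. Compound 3 thus stands at the limit alongside the others. Compound 4 `Cc1ccccc1-n1cc(CNC(=O)c2cccc3c2cnn3C(C)C)nn1` differs from compound 3 by 2-methylphenyl in place of 4-methylphenyl on an aromatic nitrogen. Going by the values given here, no measured step offers a readable size, so no change beyond the scatter is expected in this assay. Compound 4 is expected to give 40000 nM, between 20000 nM and 80000 nM, most likely again only as a limit. That expectation amounts to a step of a number no higher from compound 3 to compound 4 (the limit leaves the size open).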

Compound 4, half-maximal inhibitory concentration: > 40000 nM
Compound 4: a limit, no number (the forecaster's own chance of this, stated with the estimate: 85%); the middle value lies on the limit itself.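

Compound 4 gives no readable step against compound 1, compound 2 or compound 3, because all four stop at a limit rather than a number: the limit of > 40000 nM in this assay, at which 4 of the 4 values shown sit. Going by these compounds, how strongly any of them inhibits these cells, and whether their phenyl groups differ in effect, stays open.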